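The source may report more compounds than this note shows. Statements on the series, on what has been measured and on what is new or still open speak of the compounds shown alone.

- compound 1 `C/C(=N\NC(N)=S)c1ccc2[nH]c(-c3ccc(Cl)cc3)nc2c1`: > 100000 nM (a limit of the assay, not a number)
- compound 2 `C/C(=N\NC(N)=S)c1ccc2c(c1)nc(-c1ccccc1)n2C1CCCCC1`: 38000 nM

Among the measured compounds shown here, in an ADME assay on BHK-21 cells (Mesocricetus auratus) for cytotoxicity, read by MTT assay (a higher number here means that more compound is tolerated, a lower number that less compound is tolerated), compound 2 gives 38000 nM as the only exact number so far. Compound 1 gives > 100000 nM and that figure is a limit of the assay. Compound 3 `C/C(=N\NC(N)=S)c1ccc2c(c1)nc(-c1ccc(Cl)cc1)n2C1CCCCC1` is compound 2 with one change: chloro in place of hydrogen on an aromatic carbon (chloro in place of hydrogen on an aromatic carbon, para to a large group, so phenyl becomes 4-chlorophenyl). For the measured compounds named here, no two measured compounds differ in one place only, so no measured step can serve as a guide. Going by the values given here, the single anchor is compound 2 at 38000 nM and the change is expected to move this assay slightly downward at most, with no shift beyond the usual scatter of repeat measurements. The expected step of a 1.3-fold lower number from compound 2 to compound 3 (0.10 log units; within the scatter) stays inside that scatter. Compound 3 is estimated at 30000 nM with an expected range from 12000 nM to 80000 nM as its bounds.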

Compound 3, half-maximal cytotoxic concentration: > 100000 nM
Compound 3: only a limit was reported; the forecaster's own chance of this, stated with the estimate: 12%; at least 3.3-fold (0.52 log units) between middle value and limit.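

In this assay, among the compounds shown here, going from phenyl to 4-chlorophenyl gives an at least 2.6-fold higher number from compound 2 to compound 3 (0.42 log units; beyond the scatter), the first single change here whose direction can be read: with the cyclohexyl group in place, chloro on this aromatic carbon goes with more compound being tolerated, not less. As far as these compounds go, compound 3 gives > 100000 nM, which is a limit of the assay and not a number, and the true size of the step therefore stays unknown. The step from compound 1 to compound 3, which puts cyclohexyl in place of hydrogen on an aromatic nitrogen, cannot be read, as both values are limits: the limit of > 100000 nM in this assay, at which 2 of the 3 values shown sit.

From the compounds shown here alone, whether fluoro, methoxy or an amine at the same place would move this assay in the same direction stays open. So does whether chloro has this effect when hydrogen replaces the cyclohexyl group.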